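A few compounds are considered here, and "the series" means these few. Any claim that something is new, unique, unknown or untested is made for them only; others in the source may bear on it.

In a functional assay on HeLa cells (Homo sapiens) for inhibition, read by CCK-8 assay, with a stated time of 48 h (on this read-out higher numbers stand for weaker inhibition and lower numbers for stronger inhibition), the compounds measured so far read:

- Compound 1 `O=S(=O)(NCCNC(=S)Nc1cccc(Cl)c1)c1ccc(-c2ccccc2OCc2cccc(O)c2)s1`: 10700 nM
- Compound 2 `O=[N+]([O-])c1ccc(NC(=S)NCCNS(=O)(=O)c2ccc(-c3ccccc3O[C@H]3CC[C@@H](O)CC3)s2)cc1`: > 20000 nM, a limit of the assay
- Compound 3 `O=S(=O)(NCCNC(=S)Nc1cccc(Cl)c1)c1ccc(-c2ccccc2OCc2ccccc2)s1`: 8400 nM

Within the data shown here, compound 3 cannot be separated from the only other number on the scale, the measured step being a 1.3-fold lower number from compound 1 to compound 3 (0.11 log units; within the scatter). Compound 4 `O=C(NCCNS(=O)(=O)c1ccc(-c2ccccc2OCc2ccccc2)s1)Nc1cccc([N+](=O)[O-])c1` differs from compound 3 by one change: a group of 12 heavy atoms (7 carbon, 2 nitrogen, 3 oxygen; one six-membered aromatic ring of carbon only) in place of a group of 10 heavy atoms (7 carbon, 1 nitrogen, 1 sulfur, 1 chlorine; one six-membered aromatic ring of carbon only), on an amine nitrogen. Among the measured compounds shown here, no measured step touches this place. For the measured compounds named here, the one step available, a hydrogen in place of hydroxy on an aromatic carbon, lies elsewhere and stays within the scatter. No step beyond the scatter is therefore expected in this assay, and the expected step is a 1.3-fold higher number from compound 3 to compound 4 (0.12 log units; within the scatter). For compound 4 the estimate is 11000 nM, with an expected range from 4000 nM to 20000 nM.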

Compound 4, half-maximal inhibitory concentration: > 20000 nM
Compound 4 ended at the assay's limit; the forecaster's own chance of this, stated with the estimate: 20%; middle value at least 1.8-fold (0.25 log units) from the limit.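

In this assay, among these compounds, the place on the amine nitrogen, which no earlier step touched, turns out to matter: the change to (3-nitrophenyl)carbamoyl gives an at least 2.3-fold higher number from compound 3 to compound 4 (0.37 log units; beyond the scatter). Compound 4 gives > 20000 nM, which is a limit of the assay, so the true size of this step remains unknown: the limit of > 20000 nM in this assay, at which 2 of the 4 values shown sit.

The change swaps sulfur for the carbonyl oxygen and chlorine for nitro together, so the compounds shown leave open which of the two carries the step. As far as these compounds go, how a methoxy or trifluoromethyl group on that aromatic ring would read also stays open.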